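A few compounds are considered here, and "the series" means these few. Any claim that something is new, unique, unknown or untested is made for them only; others in the source may bear on it.

Working notes on the series. Going by the values given here, in a functional assay on A-375 cells (Homo sapiens) for antiproliferative activity, read by CCK-8 assay, with a stated time of 72 h, tested at 2 uM (a lower number here means a weaker effect, a higher number a stronger effect of the compound at the concentration tested), compound 1 `Nc1ccccc1NC(=O)c1ccc(CSC(=S)N2CCN(c3ccncc3)CC2)cc1` gives 85.7%, the highest of the three numbers measured so far. Compound 2 `CN(C(=S)SCc1ccc(C(=O)Nc2ccccc2N)cc1)c1cccnc1` gives 26.5% in this assay, and compound 3 `Nc1ccccc1NC(=O)c1ccc(CSC(=S)N2CCCC2)cc1` gives 30.2%. Among the compounds with values here, the one measured step, a number 3.7 percentage points higher from compound 2 to compound 3 (within the scatter), concerns the group on the thiocarbonyl carbon and lies within the scatter; it does not touch the part of compound 1 that is altered next.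

Compound 4 `Nc1ccccc1NC(=O)c1ccc(CSC(=S)N2CCN(c3ccccc3)CC2)cc1` differs from compound 1 as follows: phenyl in place of pyridin-4-yl on an amine nitrogen in a ring. The change keeps the six-membered non-aromatic ring with 2 nitrogen and its thiocarbonyl attachment intact, which is the part that separates compound 1 from compound 2 and compound 3. Within the data shown here, no measured step bears directly on exchanging the group on the ring nitrogen, so the expectation rests on compound 1 alone. The number for compound 4 in this assay is expected to stay close to that of compound 1, with a step of a number 9.7 percentage points lower from compound 1 to compound 4 (within the scatter), not beyond the scatter. Compound 4 is estimated at 76%, within a range of 50% to 92%.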

Compound 4, a percentage reported as inhibition, at one concentration (the size of the read-out at that concentration, not a potency): 27.5%
The estimate for compound 4 lay 48.5 percentage points above the measured number; the measured number lies below the stated range.
By their numbers in this assay, from the lowest: compounds 2, 4 and 3 (each within the scatter of the next); then compound 1.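

The exchange of pyridin-4-yl for phenyl on the amine nitrogen in the ring gives a number 58.2 percentage points lower from compound 1 to compound 4 (beyond the scatter) in this assay, so this position strongly affects the read-out, even though the two groups have the same number of heavy atoms. The six-membered non-aromatic ring with 2 nitrogen and its thiocarbonyl attachment are retained in compound 4, so they are not sufficient on their own for the number of compound 1, 85.7%, and the aromatic ring's hetero atom is the only point of difference. Nothing available explains why this exchange has so large an effect.

As far as these compounds go, it remains open whether the effect depends on the location of the ring nitrogen, as pyridin-2-yl or pyridin-3-yl on this ring nitrogen would show. Pyrimidin-4-yl, benzyl or a plain methyl group at the same place would show how far the high number extends beyond pyridin-4-yl.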